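The source may report more compounds than this note shows. Statements on the series, on what has been measured and on what is new or still open speak of the compounds shown alone.

Among the measured compounds shown here, compound 1 `Cn1c(-c2ccc(F)cc2)nc2c(NC3CCCC3)ncnc21` is one of three compounds measured in an assay on CHO cells for displacement of a labelled ligand from adenosine receptor A3 (Homo sapiens), read by scintillation counting, with a stated time of 3 h; a lower number here means a stronger inhibitor, a higher number a weaker inhibitor; in that assay compound 1 gives 1140 nM. Compound 2 `CCn1c(-c2ccccc2)nc2c(NC3CCCCC3)ncnc21` gives 707 nM in this assay, and compound 3 `CCCn1c(-c2ccccc2)nc2c(NC3CCCC3)ncnc21` gives 749 nM. Compound 1 has the highest of the three numbers, yet its gaps to compound 2 and to compound 3 both lie within the usual scatter, so the three compounds cannot be ranked against each other on these data. Compound 4 `Cn1c(-c2ccc(O)cc2)nc2c(NC3CCCC3)ncnc21` is obtained from compound 1 by one change: hydroxy in place of fluoro on an aromatic carbon. For the measured compounds named here, no measured pair in this set shows what such a change does, so only the numbers of compound 1 guide the expectation. The step from compound 1 to compound 4 in this assay is expected to be small, a 1.3-fold lower number from compound 1 to compound 4 (0.10 log units; within the scatter), not clearly beyond the scatter in either direction. Compound 4 is therefore expected to give about 900 nM in this assay, with a likely range from 300 nM to 3000 nM.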

Compound 4, inhibition constant: 521 nM
Compound 4: middle estimate off by 1.7-fold (0.24 log units), on the high side; low and high end bracket the measured number.
By their numbers in this assay, from the lowest: compounds 4, 2, 3 and 1 (each within the scatter of the next, the first and the last beyond it).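

Hydroxy in place of fluoro on this aromatic carbon gives a 2.2-fold lower number from compound 1 to compound 4 (0.34 log units; beyond the scatter) in this assay. Among the compounds shown here, this is the first step in the set that isolates one change, and it shows that the number responds to the group at this position, though only modestly. The 4-hydroxyphenyl group, with its hydrogen-bond donor and acceptor, is accepted here, yet nothing available explains the step.

From the compounds shown here alone, whether an amine or a methoxy group at this position would move the number further remains open. So does whether the same change gives a similar step with an ethyl or propyl chain in place of the methyl.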